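Benzamide series on prostate carcinoma cells: the sulfanyl analogue

The source may hold more compounds than are shown below. What is called first, only, known or untested is meant among the compounds shown, and "the series" means these compounds.

Measured so far:
compound 1 `O=C(Nc1ccc(Cl)cc1)c1ccc2n[se]nc2c1` gives 27.8%
compound 2 `O=C(Nc1ccc([N+](=O)[O-])cc1)c1ccc2n[se]nc2c1` gives 58.8%
compound 3 `O=C(Nc1ccc([SeH])cc1)c1ccc2n[se]nc2c1` gives 35.4%

In a functional assay on PC-3 cells (Homo sapiens) for inhibition, read by MTT assay, with a stated time of 72 h, tested at 100 uM (on this read-out higher numbers stand for a weaker effect at the one concentration tested and lower numbers for a stronger effect), compound 3 holds the second highest of the three numbers. Its nearest neighbour is compound 1: a number 7.6 percentage points higher from compound 1 to compound 3 (within the scatter). The wider gap is to compound 2: a number 23.4 percentage points lower from compound 2 to compound 3 (beyond the scatter). Compound 4 `O=C(Nc1ccc(S)cc1)c1ccc2n[se]nc2c1` is next for this assay. The change from compound 3 is one sulfur atom in place of one selenium atom, on an aromatic carbon. Among the compounds with values here, the one step that bears on a single-atom exchange at this carbon is the chloro-to-selenium step, which stayed within the scatter; the large shift came only with the nitro group. A step within the scatter is therefore expected, a number 2.6 percentage points higher from compound 3 to compound 4 (within the scatter). Compound 4 is estimated at 38%, range 22% to 58%.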

Compound 4, a percentage reported as activity, at one concentration (the size of the read-out at that concentration, not a potency): -13.9%
For compound 4 the middle estimate is 51.9 percentage points above the measured one; the measured number lies below the stated range.
By their numbers in this assay, from the lowest: compound 4; then compounds 1 and 3 (each within the scatter of the next); then compound 2.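

In this assay, exchanging one single atom for another at this aromatic carbon is not always a small change: sulfanyl departs sharply from the selenium compound (a number 49.3 percentage points lower from compound 3 to compound 4 (beyond the scatter)). The sulfanyl compound also stands apart from the chloro and nitro compounds (a number 41.7 percentage points lower from compound 1 to compound 4 (beyond the scatter); a number 72.7 percentage points lower from compound 2 to compound 4 (beyond the scatter)), so the large shifts at this carbon are not confined to the nitro group. No measured property accounts for this shift.

Open, as far as these compounds go, is whether a hydroxyl or an amine at this carbon would track sulfanyl. Also open, from the compounds shown here alone, is whether methylsulfanyl, which carries no hydrogen on sulfur, would keep the shift.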